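Compound 4: a nitro group added to compound 3

The source may report more compounds than this note shows. Statements on the series, on what has been measured and on what is new or still open speak of the compounds shown alone.

In a functional assay on SGC-7901 cells (Homo sapiens) for antiproliferative activity, read by MTT assay, with a stated time of 72 h (on this read-out lower numbers stand for stronger inhibition and higher numbers for weaker inhibition), compound 1 (`COc1ccc(-c2ssc(=O)c2-c2cc(OC)c(OC)c(OC)c2)cc1`) gives 134 nM and compound 2 (`COc1ccc(-c2ssc(=O)c2-c2cc(OC)c(OC)c(OC)c2)cc1O`) gives 3110 nM as its measured value. For compound 3 (`COc1ccc(-c2c(-c3cc(OC)c(OC)c(OC)c3)ssc2=O)cc1`) the result > 100000 nM is a limit and not a number. Compound 4 (`COc1ccc(-c2c(-c3cc(OC)c(OC)c(OC)c3)ssc2=O)cc1[N+](=O)[O-]`) is compound 3 with nitro in place of hydrogen on an aromatic carbon, ortho to a methoxy group and meta to a large group (nitro in place of hydrogen on an aromatic carbon). Going by the values given here, the one measured step of a similar kind, hydroxy in place of hydrogen on an aromatic carbon, is a 23-fold higher number from compound 1 to compound 2 (1.37 log units; beyond the scatter) and so a large move toward weaker inhibition. It involves another group on another parent, so it guides only loosely, but it offers no hint of a gain. No clear step is therefore expected in this assay for this change. The estimated step is a number no higher from compound 3 to compound 4 (the limit leaves the size open) at most a modest one. Compound 4 is expected at 100000 nM with an estimated range of 20000 nM to 300000 nM in this test.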

Compound 4, half-maximal inhibitory concentration: > 100000 nM
Compound 4: only a limit was reported; the forecaster's own chance of this, stated with the estimate: 65%; the middle value lies on the limit itself.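

Compound 3 and compound 4 both end at a limit and not at a number in this assay, so the step between them cannot be read: the limit of > 100000 nM in this assay, at which 2 of the 4 values shown sit.

As far as these compounds go, what stays open is whether nitro in place of hydrogen changes the activity at all, and how far past the limit each compound lies.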